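Dimethylamino in Place of Hydroxy: Expected Dose

The compounds below may be only part of what the source reports. "The series", "measured", "known", "first", "only" and "open" are said of these compounds alone.

Measured compounds in a functional assay on the whole organism with Mus musculus as the target, in the maximal electroshock model, with a stated time of 30 min; a lower number here means that less compound is needed, a higher number that more compound is needed for the effect:
compound 1, `O=C(Nc1ccncc1)Nc1ccccc1[N+](=O)[O-]`, gives 300 mg/kg.
compound 2, `CC(C)c1ccccc1NC(=O)Nc1ccncc1`, gives 100 mg/kg.
compound 3, `O=C(Nc1ccncc1)Nc1ccccc1O`, reaches only the limit of the assay and gives > 300 mg/kg.

Among the measured compounds shown here, compound 3 is thus the one compound for which no number is known, only a limit (the limit of > 300 mg/kg in this assay, at which 1 of the 3 values shown sits). Compound 4, `CN(C)c1ccccc1NC(=O)Nc1ccncc1`, differs from it at one position: dimethylamino in place of hydroxy on an aromatic carbon. For the measured compounds named here, two measured steps bear on this change, since both end in the hydroxy compound. The step of an at least 3.0-fold higher number from compound 2 to compound 3 (0.47 log units; beyond the scatter) shows that bringing in hydroxy raised the dose at least modestly. The step of a number no lower from compound 1 to compound 3 (the limit leaves the size open) leaves the size open, but the hydroxy compound needed no less than the nitro compound. Taking hydroxy away again is therefore expected to lower the number in this assay by a modest amount, in the direction of compound 2. Compound 4 is estimated to give 200 mg/kg, with a range from 100 mg/kg to 300 mg/kg. The expected step is an at least 1.5-fold lower number from compound 3 to compound 4 (0.17 log units; that floor lies within the scatter).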

Compound 4, minimum effective dose: 100 mg/kg
The estimate for compound 4 lay 2.0-fold (0.30 log units) above the measured number; measured number inside the range.
By their numbers in this assay, from the lowest: compounds 2 and 4 (each within the scatter of the next); then compound 1.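

In this assay this position on the aromatic ring, which has held nitro, isopropyl and hydroxy, also takes dimethylamino, and replacing hydroxy with it gives an at least 3.0-fold lower number from compound 3 to compound 4 (0.47 log units; beyond the scatter) as the step. Replacing isopropyl with dimethylamino gives no change at the digits printed from compound 2 to compound 4 (within the scatter) and replacing nitro with it gives a 3.0-fold lower number from compound 1 to compound 4 (0.48 log units; beyond the scatter) in this assay and so a group attached through nitrogen does as well here as isopropyl, which is attached through carbon. The true size of the step away from hydroxy stays open because compound 3 stands at a limit: the limit of > 300 mg/kg in this assay, at which 1 of the 4 values shown sits.

The compounds shown leave open whether a primary amine or a methoxy group would match dimethylamino at this place. They also leave open how a carboxylic acid or a longer chain would fare there.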